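A few compounds are considered here, and "the series" means these few. Any claim that something is new, unique, unknown or untested is made for them only; others in the source may bear on it.

For the measured compounds named here, in a functional assay on MCF7 cells (Homo sapiens) for inhibition (a higher number here means a weaker inhibitor, a lower number a stronger inhibitor), compound 1 `C=CCC1=C(O)S[C@](C)(CCCCCCCC)C1=O` gives 34.8 ug/mL, the only single number available for it, and compound 2 `CCCCCCCC[C@@]1(C)SC(O)=C(C(C)O)C1=O` gives 17.6 ug/mL; 21.7 ug/mL (2 entries). These values lie within the usual scatter of each other. Compound 3 `CCCCCCCC[C@@]1(C)SC(O)=C(C(=O)C(F)(F)F)C1=O` has not yet been measured. It carries (trifluoromethyl)carbonyl in place of the allyl of compound 1 on a double-bonded ring carbon ((trifluoromethyl)carbonyl in place of allyl on a double-bonded ring carbon). Going by the values given here, no measured step shows what such a swap does, so the change expected in this assay stays within the usual scatter, in neither direction clearly: the expected step is a 1.4-fold lower number from compound 1 to compound 3 (0.14 log units; within the scatter). For compound 3 the estimated value is 25 ug/mL, with a range of 10 ug/mL to 60 ug/mL.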

Compound 3, half-maximal inhibitory concentration: 14.7 ug/mL
Beside the measured number, compound 3's estimate is 1.7-fold (0.23 log units) above it; low and high end bracket the measured number.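

This position, on a double-bonded ring carbon next to the ring atom that bears a hydroxy group, now gives its first readable step: in this assay, (trifluoromethyl)carbonyl in place of allyl gives a 2.4-fold lower number from compound 1 to compound 3 (0.37 log units; beyond the scatter) toward a stronger inhibitor. The step is modest, and repeat entries of one compound also differ somewhat: the several entries of compound 2 in this assay, 17.6 ug/mL; 21.7 ug/mL (2 entries).

The compounds shown leave open whether the carbonyl or the trifluoromethyl carries this step; an acetyl group at this position would separate the two. From the compounds shown here alone, how an amine there would behave also stays open.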